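Replacing (methylsulfonyl)carbamoyl with 1H-tetrazol-5-yl on the chain

The source may hold more compounds than are shown below. What is called first, only, known or untested is meant among the compounds shown, and "the series" means these compounds.

Compound 1 `O=C(O)CCCCCCCn1nc(-c2ccccc2)c(-c2ccccc2)c1-c1ccccc1`: 3400 nM
Compound 2 `O=C(O)COCCCCCCn1nc(-c2ccccc2)c(-c2ccccc2)c1-c1ccccc1`: 440 nM
Compound 3 `CS(=O)(=O)NC(=O)CCCCCCCCn1nc(-c2ccccc2)c(-c2ccccc2)c1-c1ccccc1`: 5900 nM

In a functional assay for inhibition, with Homo sapiens as the target (on this read-out higher numbers stand for weaker inhibition and lower numbers for stronger inhibition), compound 3 gives 5900 nM, which matches compound 1 within the scatter and sits well apart from compound 2. Compound 4 `c1ccc(-c2nn(CCCCCCCCc3nnn[nH]3)c(-c3ccccc3)c2-c2ccccc2)cc1` puts 1H-tetrazol-5-yl in place of (methylsulfonyl)carbamoyl on a saturated chain carbon, eight bonds along the chain from an aromatic nitrogen. Among the compounds with values here, the closest precedent is a 1.7-fold higher number from compound 1 to compound 3 (0.24 log units; within the scatter), which also exchanges one group for another on the chain. The larger 7.7-fold lower number from compound 1 to compound 2 (0.89 log units; beyond the scatter) and a 13-fold higher number from compound 2 to compound 3 (1.13 log units; beyond the scatter) both involve carboxymethoxy, and compound 4 carries none. No step beyond the scatter is therefore expected in this assay. The expected change is a 1.5-fold lower number from compound 3 to compound 4 (0.17 log units; within the scatter). Compound 4 is estimated at 4000 nM, with an expected range of 1200 nM to 13000 nM.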

Compound 4, half-maximal inhibitory concentration: 1040 nM
Beside the measured number, compound 4's estimate is 3.8-fold (0.59 log units) above it, and the stated range ends above it.
By their numbers in this assay, from the lowest: compound 2; then compound 4; then compounds 1 and 3 (each within the scatter of the next).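

In this assay the group at the chain end does matter: 1H-tetrazol-5-yl in place of (methylsulfonyl)carbamoyl gives a 5.7-fold lower number from compound 3 to compound 4 (0.75 log units; beyond the scatter) and so goes beyond the scatter, unlike the earlier exchange with carboxy. Against the carboxy chain the new group gives a 3.3-fold lower number from compound 1 to compound 4 (0.51 log units; beyond the scatter) while against the carboxymethoxy chain it gives a 2.4-fold higher number from compound 2 to compound 4 (0.37 log units; beyond the scatter) and so falls short of that compound. Nothing available explains these differences. Still open, as far as these compounds go, is whether 1H-tetrazol-5-yl gains further on a chain holding the oxygen of compound 2. From the compounds shown here alone, a shorter chain or an amine at the chain end also remains untested here.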